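Chain Extension in a Triazole Series: Expected Cytotoxicity

The source may hold more compounds than are shown below. What is called first, only, known or untested is meant among the compounds shown, and "the series" means these compounds.

Compound 1, `CC[C@H](CCn1cncn1)c1ccccc1`, gives 97.7 ug/mL in an ADME assay on HEp-2 cells (Homo sapiens) for cytotoxicity, read by MTT assay, with a stated time of 3 days; a higher number here means that more compound is tolerated, a lower number that less compound is tolerated.
Compound 2, `CC[C@@H](CCn1cncn1)c1ccccc1`, gives 89.9 ug/mL in this assay.
Compound 3, `CC[C@H](CCn1cncn1)c1ccc(C)cc1`, gives 75.2 ug/mL in this assay.

Among these three, compound 1 gives the highest number, yet the gaps to the others stay within the usual scatter: a 1.1-fold lower number from compound 1 to compound 2 (0.04 log units; within the scatter) and a 1.3-fold lower number from compound 1 to compound 3 (0.11 log units; within the scatter). The first of these rests on (the fact that compounds 1 and 2 differ only in the configuration as drawn).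

Compound 4, `CCC[C@H](CCn1cncn1)c1ccccc1`, differs from compound 1 by methyl in place of hydrogen on a saturated chain carbon, three bonds along the chain from an aromatic carbon. Among the measured compounds shown here, no measured step shows this change on a saturated chain carbon; the closest comparison is the added methyl in the step from compound 1 to compound 3, which stayed within the scatter, and the configuration change also stayed within it. A small change of this kind is therefore expected to give no step beyond the scatter in this assay. For compound 4 the estimate is 88 ug/mL, with a range from 50 ug/mL to 150 ug/mL, meaning an expected 1.1-fold lower number from compound 1 to compound 4 (0.05 log units; within the scatter).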

Compound 4, half-maximal cytotoxic concentration: 58.4 ug/mL
For compound 4 the middle estimate is 1.5-fold (0.18 log units) above the measured one; low and high end bracket the measured number.
By their numbers in this assay, from the lowest: compounds 4, 3, 2 and 1 (each within the scatter of the next).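

In this assay this chain position now has a measured step of its own: methyl in place of hydrogen on a saturated chain carbon, three bonds along the chain from an aromatic carbon, gives a 1.7-fold lower number from compound 1 to compound 4 (0.22 log units; within the scatter) and so stays within the scatter. Going from ethyl to propyl here therefore behaves like the earlier methyl change on the aromatic carbon. Nothing at hand bears on why this step has the size it has.

Going by these compounds, whether a longer chain, such as butyl, would also stay within the scatter remains open. So does the effect of an amine or a carboxylic acid on this saturated chain carbon.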